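Cyclopropyl in Place of Vinyl at the Chain End

The source may report more compounds than this note shows. Statements on the series, on what has been measured and on what is new or still open speak of the compounds shown alone.

Measured in a functional assay on HEK293 cells with transient receptor potential cation channel subfamily V member 1 (Homo sapiens) as the target; a higher number here means that more compound is needed for the effect, a lower number that less compound is needed:
Compound 1 `COc1cc(CNC(=O)/C=C(\C)CC/C=C(\C)CCC=C(C)C)ccc1O`: 0.501 nM
Compound 2 `C=C(C)[C@H]1CC=C(C(=O)NCc2ccc(O)c(OC)c2)CC1`: 794 nM
Compound 3 `C=CCCCCCCCCC(=O)NCc1ccc(O)c(OC)c1`: 2 nM

Among these three numbers compound 3 stands second highest. Compound 1 is nearest, with a lower number that still lies beyond the usual scatter, and compound 2 is furthest, with a far higher number. Compound 4 `COc1cc(CNC(=O)CCCCCCCCC2CC2)ccc1O` has not yet been measured in this assay. It differs from compound 3 in one place: cyclopropyl in place of vinyl on a saturated chain carbon, eight bonds along the chain from a carbonyl carbon. Going by the values given here, no measured pair shows this change, so the expectation rests on the structures alone. Only a small step is expected, and its direction is open; the expected step reads a 1.3-fold higher number from compound 3 to compound 4 (0.10 log units; within the scatter). Compound 4 is expected to give 2.5 nM, within a range from 0.7 nM to 8 nM.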

Compound 4, half-maximal effective concentration: 3.16 nM
Compound 4: middle estimate off by 1.3-fold (0.10 log units), on the low side; low and high end bracket the measured number.
By their numbers in this assay, from the lowest: compound 1; then compounds 3 and 4 (each within the scatter of the next); then compound 2.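

In this assay, cyclopropyl in place of vinyl gives a step that stays within the usual scatter (a 1.6-fold higher number from compound 3 to compound 4 (0.20 log units; within the scatter)). On a saturated chain carbon, eight bonds along the chain from a carbonyl carbon, the double bond of vinyl is therefore not needed to keep a low number, and a three-membered carbon ring serves as well. No supporting measurement explains why the two groups read alike. As far as these compounds go, whether cyclobutyl, an amine or a carboxylic acid would be accepted at this place stays open. So does whether the same change would read alike on a shorter chain.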